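Swapping the aryl group on the exocyclic carbon: compound 3 pending

The source may report more compounds than this note shows. Statements on the series, on what has been measured and on what is new or still open speak of the compounds shown alone.

Measured so far:
compound 1 `CCOC(=O)C1=C(Nc2ccccc2)S/C(=C\c2ccc(O)c(O)c2)C1=O`: 48.7%
compound 2 `CCOC(=O)C1=C(Nc2ccccc2)S/C(=C\c2ccc[nH]2)C1=O`: 49.2%
compound 3 `CCOC(=O)C1=C(Nc2ccccc2)S/C(=C\c2cc3ccncc3[nH]2)C1=O`: to be measured

In a functional assay on JAR cells (Homo sapiens) for inhibition, read by MTT assay, with a stated time of 72 h, tested at 10 uM (on this read-out higher numbers stand for more inhibition at the one concentration tested (going by the name of the read-out) and lower numbers for less inhibition), compound 1 gives 48.7% and compound 2 gives 49.2%. Going by the values given here, compound 2 carries the higher of the two numbers, but its only neighbour is compound 1, and the step of a number 0.5 percentage points higher from compound 1 to compound 2 (within the scatter) lies within the scatter, so the two compounds cannot be told apart on this read-out.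

The change from compound 2 to compound 3 is a group of 9 heavy atoms (7 carbon, 2 nitrogen; one five-membered aromatic ring with 1 hetero atom, one six-membered aromatic ring with 1 hetero atom) in place of a group of 5 heavy atoms (4 carbon, 1 nitrogen; one five-membered aromatic ring with 1 hetero atom), on a double-bonded chain carbon bound to a double-bonded ring carbon. Among the compounds with values here, the one measured step that bears on this place is a number 0.5 percentage points higher from compound 1 to compound 2 (within the scatter), where one aryl group replaced another on the same carbon without a shift beyond the scatter. Within the data shown here, nothing among the measured compounds speaks to the entering group itself, so the expectation rests on that single step alone. No direction is favoured, and the expected step is a number 0.8 percentage points higher from compound 2 to compound 3 (within the scatter). Compound 3 is accordingly estimated at 50%, with a range from 32% to 68%.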

Compound 3, a percentage reported as inhibition, at one concentration (the size of the read-out at that concentration, not a potency): 26.3%
The estimate for compound 3 lay 23.7 percentage points above the measured number, outside the stated range (below it).
By their numbers in this assay, from the lowest: compound 3; then compounds 1 and 2 (each within the scatter of the next).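

In this assay, the group on the double-bonded chain carbon bound to a double-bonded ring carbon proves able to move the number, which the earlier pair did not show: the change gives a number 22.9 percentage points lower from compound 2 to compound 3 (beyond the scatter) and a number 22.4 percentage points lower from compound 1 to compound 3 (beyond the scatter). Compared with 1H-pyrrol-2-yl, the entering group keeps a five-membered aromatic ring with 1 hetero atom and a hydrogen-bond donor while adding a six-membered aromatic ring with 1 hetero atom and a hydrogen-bond acceptor, so keeping those first two features does not by itself hold the number at the level seen for compound 1 and compound 2. No measurement at hand accounts for the lower number.

The compounds shown do not tell whether the lower number follows from the added ring as a whole or from its nitrogen, a question that an indol-2-yl group, with carbon in place of that ring nitrogen, would address. They also leave open how a carboxylic acid in place of the ethyl ester on the shared core would read out alongside these aryl groups.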